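Hydroxy Substitution on Two Related Macrocyclic Cores

A few compounds are considered here, and "the series" means these few. Any claim that something is new, unique, unknown or untested is made for them only; others in the source may bear on it.

Compound 1, with the structure `CC[C@H](C)[C@H]1C(=O)N[C@H](Cc2cc(Cl)c(O)c(Cl)c2)C(=O)N[C@@H](C(C)C)C(=O)O[C@H](c2ccccc2)[C@H](C)/C=C/C=C(\C)[C@H](OC)C[C@@H]2O[C@@]2(C)C(=O)N1C`, is the starting point of this small set. In a functional assay on HCT-116 cells (Homo sapiens) for antiproliferative activity (a lower number here means a stronger inhibitor, a higher number a weaker inhibitor), compound 1 gives 4.25 nM. Compound 2, `CC[C@H](C)[C@H]1C(=O)N[C@H](Cc2cc(Cl)c(O)c(Cl)c2)C(=O)N[C@@H](C(C)(C)O)C(=O)O[C@H](c2ccccc2)[C@H](C)/C=C/C=C(\C)[C@H](OC)C[C@@H]2O[C@@]2(C)C(=O)N1C`, differs from compound 1 in one place: hydroxy in place of hydrogen on a saturated chain carbon bound to two saturated chain carbons and a saturated ring carbon. In this assay compound 2 gives 2.11 nM, and the step is a 2.0-fold lower number from compound 1 to compound 2 (0.30 log units; within the scatter). The two values therefore cannot be told apart with confidence.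

Compound 3, `CC[C@H](C)[C@H]1C(=O)N[C@H](Cc2cc(Cl)c(O)c(Cl)c2)C(=O)N[C@@H](C(C)C)C(=O)O[C@H](c2ccccc2)[C@H](C)/C=C/C=C(\C)[C@H](OC)C/C=C(\C)C(=O)N1C`, carries a different core; the difference between the two cores is not broken down here. In this assay compound 3 gives 21.6 nM, the highest number of the three measured compounds, and its separation from compound 1 and compound 2 lies beyond the usual scatter.

Compound 4, `CC[C@H](C)[C@H]1C(=O)N[C@H](Cc2cc(Cl)c(O)c(Cl)c2)C(=O)N[C@@H](C(C)(C)O)C(=O)O[C@H](c2ccccc2)[C@H](C)/C=C/C=C(\C)[C@H](OC)C/C=C(\C)C(=O)N1C`, is not yet measured. It stands to compound 3 exactly as compound 2 stands to compound 1: hydroxy in place of hydrogen on a saturated chain carbon bound to two saturated chain carbons and a saturated ring carbon. The place of the change is described in the same words in both pairs, so this is the same change made on a second core.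

Given that the only precedent for this change is a step within the scatter, the expected step for compound 4 is modest: a 2.0-fold lower number from compound 3 to compound 4 (0.29 log units; within the scatter). That expectation rests on the earlier pair, where a 2.0-fold lower number from compound 1 to compound 2 (0.30 log units; within the scatter). For compound 4 the estimated value in this assay is 11 nM, expected to fall between 5 nM and 25 nM.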

Compound 4, half-maximal inhibitory concentration: 1.6 nM
Beside the measured number, compound 4's estimate is 6.9-fold (0.84 log units) above it, outside the stated range (below it).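

In this assay, replacing isopropyl with 1-hydroxy-1-methylethyl on the core of compound 3 gives a 14-fold lower number from compound 3 to compound 4 (1.13 log units; beyond the scatter), so the change counts for much more here than it did on the core of compound 1. Among these compounds, the size of this step therefore did not carry from one core to the other, and the two steps are truly different rather than a product of ordinary assay variation: the same change on two cores in this assay, a 2.0-fold lower number (0.30 log units; within the scatter) from compound 1 to compound 2 and a 14-fold lower number (1.13 log units; beyond the scatter) from compound 3 to compound 4, 6.7-fold (0.83 log units) apart, beyond the scatter of two such steps What this does not show is why the cores respond differently, and with only two pairs it gives no rule for predicting the size of the step on any further core, although the printed values of compound 2, 2.11 nM, and compound 4, 1.6 nM, do lie close together.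

The compounds shown leave open whether other groups at this same carbon, such as a methoxy group, an amine or a longer chain, would also respond differently on the two cores. Among the compounds shown here, they also leave open which part of the difference between the two cores matters, since no compound here separates that difference into smaller pieces.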